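The source may hold more compounds than are shown below. What is called first, only, known or untested is meant among the compounds shown, and "the series" means these compounds.

Measured so far in an assay on brain for binding affinity to Neuronal acetylcholine receptor; alpha4/beta2 (Rattus norvegicus); a higher number here means a weaker inhibitor, a lower number a stronger inhibitor:
compound 1, `Brc1ncccc1OC[C@@H]1CCN1`, 0.24 nM
compound 2, `Ic1ncccc1OC[C@@H]1CCN1`, > 0.001 nM
compound 3, `Fc1cncc(OC[C@@H]2CCN2)c1`, 0.025 nM

Compound 2 carries a limit of this assay rather than a number, the one given in the limit of > 0.001 nM in this assay, at which 1 of the 3 values shown sits. Within the data shown here, because of that limit, the single one-place step, a step that the limit leaves unreadable from compound 1 to compound 2, cannot be read for size. Among the two numbers, compound 3 holds the lower one; the nearest, from compound 1, sits higher by a gap beyond the scatter, but the two structures differ in more than one place, so no single step is drawn from them.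

The next compound, compound 4, `Brc1cncc(OC[C@@H]2CCN2)c1`, is reached from compound 3 by one change: bromo in place of fluoro on an aromatic carbon. Among the measured compounds shown here, no measured step covers a bromo entering in place of a fluoro, and the only halogen-for-halogen step, from compound 1 to compound 2, is unreadable. What remains is that compound 1, which carries a bromo on its own core, still gives 0.24 nM in this assay, so bromo at an aromatic carbon is compatible with a low number here. The expectation for compound 4 is therefore a step of a 1.4-fold higher number from compound 3 to compound 4 (0.15 log units; within the scatter), small and within or near the scatter, with a wide range in either direction. Compound 4 is estimated at 0.035 nM, between 0.008 nM and 0.15 nM.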

Compound 4, inhibition constant: 0.021 nM
Estimate against measurement, compound 4: 1.7-fold (0.22 log units) above; low and high end bracket the measured number.
By their numbers in this assay, from the lowest: compounds 4 and 3 (each within the scatter of the next); then compound 1.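

In this assay, among these compounds, bromo in place of fluoro on this aromatic carbon gives a 1.2-fold lower number from compound 3 to compound 4 (0.08 log units; within the scatter), the first halogen-for-halogen step that can be read, and it stays within the scatter. At this place, two atoms from the ring nitrogen and meta to a group of 6 heavy atoms, the two halogens therefore cannot be told apart by this read-out, and neither compound 3 nor compound 4 ranks over the other. The low number seen with fluoro is thus not particular to fluoro, though this rests on a single pair of compounds on a single core.

On these data alone, compound 2 carries a limit and not a number, so the step from bromo to iodo on the core of compound 1 cannot be read and gives no second halogen comparison: the limit of > 0.001 nM in this assay, at which 1 of the 4 values shown sits. Still open is whether iodo or chloro at the place shared by compound 3 and compound 4 would stay within the scatter of these two, and whether a non-halogen group there, such as an amine, a methoxy or a carboxylic acid, would keep a number in this range.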